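A few compounds are considered here, and "the series" means these few. Any claim that something is new, unique, unknown or untested is made for them only; others in the source may bear on it.

Working notes on the series. In a functional assay on MCF7 cells (Homo sapiens) for cytotoxicity, read by MTT assay, with a stated time of 24 h (a higher number here means a weaker inhibitor, a lower number a stronger inhibitor), compound 3 `Cn1nc(-c2ccc(C(F)(F)F)cc2)cc1-c1nnc(S)o1` gives > 100000 nM, which is a limit of the assay and not a number. The limit is recorded under (the limit of > 100000 nM in this assay, at which 1 of the 3 values shown sits). Compound 4 `Cn1nc(-c2ccc(C(F)(F)F)cc2)cc1-c1nnc(SCc2cccc(Cl)c2Cl)o1` differs from compound 3 by 2,3-dichlorobenzyl in place of hydrogen on a sulfur. Among the measured compounds shown here, no measured step covers this change. For the measured compounds named here, the only measured step is a 1.0-fold higher number from compound 1 to compound 2 (0.02 log units; within the scatter), which exchanges one benzyl group for another and says nothing about going from hydrogen to a benzyl group. Compound 1 `Cn1nc(-c2nnc(SCc3c(F)cccc3F)o2)cc1-c1ccc(C(F)(F)F)cc1` and compound 2 `Cn1nc(-c2nnc(SCc3ccc(Cl)c(Cl)c3)o2)cc1-c1ccc(C(F)(F)F)cc1` carry benzylsulfanyl groups on a core that is not the core of compound 3, and in this assay compound 1 gives 26200 nM while compound 2 gives 27200 nM. Taking these two as the nearest measured points, compound 4 is expected to sit in the same region, giving an estimated 30000 nM with a range from 9000 nM to 90000 nM. The expected step from the limit of compound 3 is therefore an at least 3.3-fold lower number from compound 3 to compound 4 (0.52 log units; beyond the scatter), a move to a measurable number, with the core difference from compounds 1 and 2 leaving the estimate uncertain.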

Compound 4, half-maximal inhibitory concentration: 60200 nM
The estimate for compound 4 lay 2.0-fold (0.30 log units) below the measured number; the range from low to high includes it.
By their numbers in this assay, from the lowest: compounds 1 and 2 (each within the scatter of the next); then compound 4. At a limit, above all of these: compound 3.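

In this assay, 2,3-dichlorobenzyl in place of hydrogen on a sulfur gives an at least 1.6-fold lower number from compound 3 to compound 4 (0.22 log units; that floor lies within the scatter), the only step shown that starts from hydrogen at this place. The floor of that step lies within the scatter, so the size of the change stays unread; what is new is that a benzyl group on this core yields a number at all. Compound 3 stands at a limit of the assay and not at a number: the limit of > 100000 nM in this assay, at which 1 of the 4 values shown sits.

Open, on these data alone, is whether a group other than benzyl on this sulfur, such as a methyl, a longer alkyl chain or a chain ending in a carboxylic acid or an amine, would also give a number in this assay. Also open, as far as these compounds go, is how other substituents on the benzyl ring read on the core of compound 4, the benzyl groups of compound 1 and compound 2 standing on a different core.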